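This account rests on a few compounds, and the source may have more. Where it says the series, first, only, none or still open, it means among the compounds named here.

In an ADME assay on CHO cells (Cricetulus griseus) for cytotoxicity (on this read-out higher numbers stand for weaker inhibition and lower numbers for stronger inhibition), the measured compounds are these, and each value is a limit of the assay and not a number:

- Compound 1 `Nc1cc(Nc2cnccn2)nc(-c2ccnc(N3CCNCC3)c2)c1` gives > 20000 nM
- Compound 2 `CC(=O)N1CCC(C(=O)Nc2cc(Nc3cnccn3)nc(-c3ccnc(N4CCNCC4)c3)c2)CC1` gives > 20000 nM
- Compound 3 `O=C(Cc1cccnc1)Nc1cc(Nc2cnccn2)nc(-c2ccnc(N3CCNCC3)c2)c1` gives > 20000 nM

Compound 1 stands at the limit > 20000 nM and has no exact number. The whole set shows the limit of > 20000 nM in this assay, at which 3 of the 3 values shown sit, and so offers no numbers to compare.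

Compound 4 `O=C(Nc1cc(Nc2cnccn2)nc(-c2ccnc(N3CCNCC3)c2)c1)c1cncnc1` carries one change from compound 1: (pyrimidin-5-yl)carbonyl in place of hydrogen on a nitrogen on an aromatic ring and so has (pyrimidin-5-yl)carbonyl in place of hydrogen on a nitrogen on an aromatic ring.

Two measured changes sit in that same place, a step that the two limits leave unreadable from compound 1 to compound 2 and a step that the two limits leave unreadable from compound 1 to compound 3 and neither has a size that can be read. They show no sign of a change, so no step beyond the usual scatter is expected, and no direction is foreseen. The expected outcome in this assay is a number no higher from compound 1 to compound 4 (the limit leaves the size open) and a reading at the limit, rather than a number, is the likely report. For compound 4 the estimated value is 20000 nM with an expected range from 8000 nM to 40000 nM and the measurement itself is still to come.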

Compound 4, half-maximal inhibitory concentration: > 20000 nM
Compound 4: no number, only a limit; the forecaster's own chance of this, stated with the estimate: 80%; the middle value lies on the limit itself.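

In this assay compound 4 gives > 20000 nM and this is a limit, not a number. Within the data shown here, no step among compound 1, compound 2, compound 3 and compound 4 can therefore be read: the limit of > 20000 nM in this assay, at which 4 of the 4 values shown sit. In this assay the compounds shown leave open how far these four differ, if they differ at all.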